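A few compounds are considered here, and "the series" means these few. Any claim that something is new, unique, unknown or untested is made for them only; others in the source may bear on it.

In a functional assay on PC-3 cells (Homo sapiens) for antiproliferative activity, read by MTT assay, with a stated time of 48 h (on this read-out lower numbers stand for stronger inhibition of growth and higher numbers for weaker inhibition of growth), compound 1 `Cc1ccc(-c2cnc(N(Cc3ccccc3)Cc3ccc(C(=O)NO)cc3)s2)cc1` gives 10400 nM, compound 2 `CCN(Cc1ccc(C(=O)NO)cc1)c1ncc(-c2ccc(C)cc2)s1` gives 10300 nM and compound 3 `CCCCCCCCN(Cc1ccc(C(=O)NO)cc1)c1ncc(-c2ccc(C)cc2)s1` gives 13300 nM, so compound 3 stands level with the other two within the scatter. Compound 4 `Cc1ccc(OCCCN(Cc2ccc(C(=O)NO)cc2)c2ncc(-c3ccc(C)cc3)s2)cc1` keeps the core of compound 3 and changes the end of its chain: 4-methylphenoxy in place of pentyl on a saturated chain carbon, three bonds along the chain from a nitrogen on an aromatic ring. Changing the group on this nitrogen has so far moved the numbers very little: a 1.0-fold lower number from compound 1 to compound 2 (0.00 log units; within the scatter), a 1.3-fold higher number from compound 1 to compound 3 (0.11 log units; within the scatter) and a 1.3-fold higher number from compound 2 to compound 3 (0.11 log units; within the scatter), all within the scatter. Going by the values given here, no measured compound carries 4-methylphenoxy, so the range stays wide. The expected change is small, an estimated 1.3-fold lower number from compound 3 to compound 4 (0.12 log units; within the scatter), with no shift beyond the scatter anticipated. Compound 4 is expected at about 10000 nM, within an estimated range of 4500 nM to 20000 nM.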

Compound 4, concentration for 50% growth inhibition: 9330 nM
Beside the measured number, compound 4's estimate is 1.1-fold (0.03 log units) above it, and the stated range covers the measured number.
By their numbers in this assay, from the lowest: compounds 4, 2, 1 and 3 (each within the scatter of the next).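

In this assay, a chain end with an aromatic ring and an ether oxygen leaves the number within the scatter of the plain alkyl chain (a 1.4-fold lower number from compound 3 to compound 4 (0.15 log units; within the scatter)). The same holds against the smaller groups on this nitrogen (a 1.1-fold lower number from compound 2 to compound 4 (0.04 log units; within the scatter)) and (a 1.1-fold lower number from compound 1 to compound 4 (0.05 log units; within the scatter)), so 4-methylphenoxy at this place, three bonds along the chain, joins the earlier groups in producing no measurable shift. No measurement at hand gives a reason for this. As far as these compounds go, whether a chain ending in an amine or a carboxylic acid would move the number beyond the scatter stays open.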